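Working notes: one stereocentre, compound 2 to compound 3

This account rests on a few compounds, and the source may have more. Where it says the series, first, only, none or still open, it means among the compounds named here.

- compound 1 `Cc1cn([C@H]2C[C@H](CC3=CC(=O)C(=O)C=C3)[C@@H](CO[Si](C)(C)C(C)(C)C)O2)c(=O)[nH]c1=O` has no result reported
- compound 2 `COc1ccc(C2([C@H]3C[C@H](n4cc(C)c(=O)[nH]c4=O)O[C@@H]3CO[Si](C)(C)C(C)(C)C)SCCCS2)cc1OC` gives 3240 nM as its growth-inhibition value

For the measured compounds named here, in a functional assay on MKN-74 cells (Homo sapiens) for inhibition, read by sulforhodamine B assay, with a stated time of 48 h (a higher number here means a weaker inhibitor of growth, a lower number a stronger inhibitor of growth), compound 2 gives 3240 nM as the only number so far, so it has no rank. Compound 3 `COc1ccc(C2([C@H]3C[C@@H](n4cc(C)c(=O)[nH]c4=O)O[C@@H]3CO[Si](C)(C)C(C)(C)C)SCCCS2)cc1OC` has yet to be measured. Against compound 2, it shows this change (the two compounds have the same atoms and bonds and differ only in configuration as drawn: 1 of 3 stereo elements differ; a stereocentre at a saturated ring carbon is drawn R in compound 2 and S in compound 3), with a stereocentre at a saturated ring carbon drawn R in compound 2 and S in compound 3. The two compounds have the same atoms and bonds. Going by the values given here, no measured step is available for calibration, so the expectation is anchored only on compound 2 at 3240 nM in this series. The estimated step of a 1.0-fold higher number from compound 2 to compound 3 (0.01 log units; within the scatter) is expected to stay inside the usual scatter, with no direction favoured. The estimate for compound 3 is 3300 nM as the expected value, with an expected range (1300 nM to 8000 nM) around it.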

Compound 3, concentration for 50% growth inhibition: 4270 nM
Beside the measured number, compound 3's estimate is 1.3-fold (0.11 log units) below it; low and high end bracket the measured number.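

In this assay, the change of one stereocentre at a saturated ring carbon from R to S gives a 1.3-fold higher number from compound 2 to compound 3 (0.12 log units; within the scatter), so the two drawn configurations at this centre are not told apart by growth inhibition. For the compounds shown here, this is the first measured step and the first reading on this position, and for this pair either configuration gives a similar value. The comparison isolates this single centre, with no other structural difference to weigh: the fact that compounds 2 and 3 differ only in the configuration as drawn

The compounds shown leave open whether the configuration at this centre would stay as silent with a free hydroxyl or an amine in place of the silyl ether. As far as these compounds go, the other two stereo elements also remain untested, so nothing can yet be said about their contribution to growth inhibition.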